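The source may hold more compounds than are shown below. What is called first, only, known or untested is meant among the compounds shown, and "the series" means these compounds.

Measured in a functional assay on P388 cells (Mus musculus) for cytotoxicity; on this read-out lower numbers stand for stronger inhibition and higher numbers for weaker inhibition:
- Compound 1 `CCCC[C@H](C)[C@H](OC(N)=O)[C@@H](C)[C@H](O)[C@@H](C)CC(C)C[C@H](C)[C@@H](O)[C@@H](C)CC[C@@H](O)C[C@@H]1OC(=O)[C@H](C)[C@@H](O)[C@H]1C`: > 8290 nM, a limit
- Compound 2 `C=C/C=C\[C@H](C)[C@H](OC(N)=O)[C@@H](C)[C@H](O)[C@@H](C)C/C(C)=C\[C@H](C)[C@H]1OC(=O)C=C[C@@H]1C`: 3690 nM
- Compound 3 `C=C/C=C\[C@H](C)[C@H](OC(N)=O)[C@@H](C)[C@H](OC(C)=O)[C@@H](C)C/C(C)=C\[C@H](C)[C@@H](O)[C@@H](C)/C=C\[C@@H](O)C[C@@H]1OC(=O)C(C)=C[C@H]1C`: > 8100 nM, a limit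

Compound 3 has no number, only (the limit of > 8100 nM in this assay, at which 1 of the 3 values shown sits). Compound 1 likewise stands at the limit of > 8290 nM in this assay, at which 1 of the 3 values shown sits. Compound 4 `C=C/C=C\[C@H](C)[C@H](OC(N)=O)[C@@H](C)[C@H](O)[C@@H](C)C/C(C)=C\[C@H](C)[C@@H](O)[C@@H](C)/C=C\[C@@H](O)C[C@@H]1OC(=O)C(C)=C[C@H]1C` differs from compound 3 by hydrogen in place of acetyl on an oxygen on a saturated carbon, that is, acetoxy to hydroxy. Going by the values given here, no measured pair shows this change directly. Compound 2 has a free hydroxy on the corresponding carbon and reads 3690 nM. Compound 1 also has a free hydroxy there and goes against any trend with its limit of > 8290 nM. A gain in strength beyond the scatter is expected, and the expected change is an at least 16-fold lower number from compound 3 to compound 4 (1.20 log units; beyond the scatter). For compound 4 the estimated value is 500 nM, with an expected range of 40 nM to 6000 nM.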

Compound 4, half-maximal inhibitory concentration: 33.6 nM
For compound 4 the middle estimate is 15-fold (1.17 log units) above the measured one; the whole stated range lies above it.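

In this assay, going by these compounds alone, hydrogen in place of acetyl on an oxygen on a saturated carbon gives an at least 240-fold lower number from compound 3 to compound 4 (2.38 log units; beyond the scatter), the first single-place change that can be read. On these data alone, for this pair, the acetyl alone separates a limit from a measured value, so the full size of the step stays unknown. The reading for compound 3 is a limit and not a number: the limit of > 8100 nM in this assay, at which 1 of the 4 values shown sits.

As far as these compounds go, whether a methyl ether or a longer acyl chain such as butyryl on this oxygen reads like acetyl or like hydrogen remains open. Also open, from the compounds shown here alone, is whether the same change has a similar effect on the core of compound 1 or compound 2.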